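The compounds below may be only part of what the source reports. "The series", "measured", "known", "first", "only" and "open" are said of these compounds alone.

In a functional assay on SW-620 cells (Homo sapiens) (a higher number here means a weaker inhibitor of growth, a lower number a stronger inhibitor of growth), compound 1 (`O=S(=O)(/C=C/c1ccc(F)cc1Cl)Cc1ccc(Nc2ncnc3ccccc23)cc1`), which carries a 2-chloro-4-fluorophenyl group, gives 100000 nM. Compound 2 (`O=S(=O)(/C=C/c1ccc(Cl)cc1Cl)Cc1ccc(Nc2ncnc3cc(Cl)ccc23)cc1`) reads > 100000 nM, which is a limit and not a number. Compound 3 (`O=S(=O)(/C=C/c1ccc(C(F)(F)F)cc1F)Cc1ccc(Nc2ncnc3cc(Cl)ccc23)cc1`) also has only a limit, > 100000 nM. This series is marked by the limit of > 100000 nM in this assay, at which 2 of the 3 values shown sit. Compound 4 (`O=S(=O)(/C=C/c1ccc(F)cc1Cl)Cc1ccc(Nc2ncnc3cc(Cl)ccc23)cc1`) has 2-chloro-4-fluorophenyl in place of 2-fluoro-4-(trifluoromethyl)phenyl on a double-bonded chain carbon bound to a double-bonded chain carbon. Within the data shown here, the only measured step at this place, a step that the two limits leave unreadable from compound 2 to compound 3, gives no size to carry over. The expectation therefore rests on compound 1 at 100000 nM, with the same group entering. The expected step, a number no higher from compound 3 to compound 4 (the limit leaves the size open), is none beyond the scatter. Compound 4 is estimated at 100000 nM, within an expected range of 50000 nM to 200000 nM.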

Compound 4, concentration for 50% growth inhibition: > 100000 nM
Compound 4: only a limit was reported (the forecaster's own chance of this, stated with the estimate: 70%); the middle value lies on the limit itself.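

In this assay compound 4 gives only a limit, > 100000 nM. The steps to it from compound 2 and from compound 3 cannot be read. The step with chloro in place of hydrogen on an aromatic carbon is a number no lower from compound 1 to compound 4 (the limit leaves the size open). With 2-chloro-4-fluorophenyl, a third group on this double-bonded chain carbon has joined the compounds that give no number, and compound 1, which has chloro replaced by hydrogen on the aromatic carbon, is the only one that does. The series is now marked by one feature: the limit of > 100000 nM in this assay, at which 3 of the 4 values shown sit. The compounds shown leave open whether any change at this place yields a readable value. A phenyl group carrying an amine or a carboxylic acid would test that.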